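Chloro for methoxy on the six-membered carbon ring

A few compounds are considered here, and "the series" means these few. Any claim that something is new, unique, unknown or untested is made for them only; others in the source may bear on it.

Within the data shown here, the two measured members are compound 1 `Cc1csc(-c2nc(N)c3cc(Cc4ccccc4)sc3n2)n1` and compound 2 `COc1ccccc1Cc1cc2c(N)nc(-c3nc(C)cs3)nc2s1`. In a functional assay on CHO-K1 cells for antagonist activity at adenosine receptor A1 (Homo sapiens), read by a beta-galactosidase reporter and cAMP accumulation, with stated times of 15 min and 6 h (a higher number here means a weaker inhibitor, a lower number a stronger inhibitor), compound 1 gives 1490 nM, and compound 2 gives 186 nM. Compound 2 therefore holds the lowest number of the two, set apart from compound 1 by the step of an 8.0-fold lower number from compound 1 to compound 2 (0.90 log units; beyond the scatter), which came with methoxy in place of hydrogen on an aromatic carbon.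

Compound 3 `Cc1csc(-c2nc(N)c3cc(Cc4ccccc4Cl)sc3n2)n1` has not yet been measured in this assay. It differs from compound 2 by chloro in place of methoxy on an aromatic carbon. Among the measured compounds shown here, only one measured step bears on this site: the step of an 8.0-fold lower number from compound 1 to compound 2 (0.90 log units; beyond the scatter) shows that adding methoxy to the six-membered carbon ring moved the number well beyond the scatter. For the measured compounds named here, no measured pair shows chloro there, so the size of its contribution is unknown; a number between the unsubstituted compound 1 and the methoxy-bearing compound 2 is the plainest reading, since chloro brings no hydrogen-bond acceptor. Compound 3 is therefore expected to come in near 400 nM in this assay, meaning a step of a 2.2-fold higher number from compound 2 to compound 3 (0.33 log units; beyond the scatter), with an expected range from 120 nM to 1300 nM.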

Compound 3, inhibition constant: 49.6 nM
The estimate for compound 3 lay 8.1-fold (0.91 log units) above the measured number, and the stated range ends above it.
By their numbers in this assay, from the lowest: compound 3; then compound 2; then compound 1.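

In this assay this place on the six-membered aromatic ring, ortho to a large group, responds far more strongly than compound 2 alone suggested: chloro in place of hydrogen gives a 30-fold lower number from compound 1 to compound 3 (1.48 log units; beyond the scatter), a step of large size. Chloro in place of methoxy gives a 3.8-fold lower number from compound 2 to compound 3 (0.57 log units; beyond the scatter), so methoxy does not mark the low end of what this place allows, and among these three compounds the lowest number goes with a group that counts no hydrogen-bond acceptor, which means an acceptor on this ring is not needed for a low number here. Nothing at hand accounts for the order of hydrogen, methoxy and chloro at this place, so the data record the ranking and not its cause.

The compounds shown leave open whether the low number belongs to chloro alone or extends to other small groups at this place, which fluoro, bromo or methyl on the same ring would help to settle. Also open, from the compounds shown here alone, is whether chloro keeps a step of this size when it stands elsewhere on the ring, or when the rest of the core of compound 1 changes.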